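From methoxy to (cyclohexylmethyl)amino on a carbonyl carbon

A few compounds are considered here, and "the series" means these few. Any claim that something is new, unique, unknown or untested is made for them only; others in the source may bear on it.

Among the compounds with values here, in a functional assay for inhibition, with Rattus norvegicus as the target, at pH 7.35 (a higher number here means a weaker inhibitor, a lower number a stronger inhibitor), compound 1 `CCC(NC(=O)C(CC(C)C)NC(=O)OCc1ccccc1)C(=O)C(=O)OC` gives 280000 nM, the highest of the numbers measured so far. Compound 3 `CCC(=O)C(=O)[C@H](CC)NC(=O)[C@H](CC(C)C)NC(=O)[C@H](CC(C)C)NC(=O)OCc1ccccc1` gives 40000 nM, lower than compound 1 by more than the scatter. Compound 2 `CCOC(=O)C(=O)C(CC)NC(=O)C(CC(C)C)NC(=O)C(c1ccccc1)c1ccccc1` reads > 100000 nM, which is a limit and not a number.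

Compound 4 `CCC(NC(=O)C(CC(C)C)NC(=O)OCc1ccccc1)C(=O)C(=O)NCC1CCCCC1` carries (cyclohexylmethyl)amino in place of methoxy on a carbonyl carbon. Within the data shown here, no measured pair isolates this change, so the expectation rests loosely on compound 3 at 40000 nM, which shows that numbers lower than that of compound 1 occur. A moderate expected move towards stronger inhibition, beyond the scatter, is a 4.0-fold lower number from compound 1 to compound 4 (0.60 log units; beyond the scatter). Compound 4 is estimated at 70000 nM, with an expected range of 12000 nM to 300000 nM.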

Compound 4, half-maximal inhibitory concentration: 66000 nM
For compound 4 the middle estimate is 1.1-fold (0.03 log units) above the measured one; the range from low to high includes it.
By their numbers in this assay, from the lowest: compounds 3 and 4 (each within the scatter of the next); then compound 1.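

In this assay, (cyclohexylmethyl)amino in place of methoxy on a carbonyl carbon whose other neighbour is a carbonyl carbon gives a 4.2-fold lower number from compound 1 to compound 4 (0.63 log units; beyond the scatter). This is the only step shown at this position, and it shows that the larger group, with its six-membered non-aromatic ring of carbon only and its hydrogen-bond donor, can stand there with a modest gain in inhibition. Nothing measured here gives a reason for the step.

As far as these compounds go, whether the ring or the amide hydrogen carries the change stays open. A simple methylamino group at this position would begin to separate the two.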